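The source may hold more compounds than are shown below. What is called first, only, known or untested is meant among the compounds shown, and "the series" means these compounds.

Working notes on the series, all read in a toxicity assay on GES1 cells (Homo sapiens) for inhibition, read by MTT assay, with a stated time of 72 h; a lower number here means a stronger inhibitor, a higher number a weaker inhibitor. Compound 1 (`O=C(NCc1ccc(NC(=O)c2ccc(F)cc2N2CCCC2)cc1)OCc1cccnc1`) gives > 100000 nM, which is a limit of the assay and not a number. Compound 2 (`COc1ccc(N2CCCC2)c(C(=O)Nc2ccc(CNC(=O)OCc3cccnc3)cc2)c1`) gives > 100000 nM, again a limit and not a number. Compound 3 (`Cc1ccc(C(=O)Nc2ccc(CNC(=O)OCc3cccnc3)cc2)c(N2CCCC2)c1`) gives > 100000 nM, also a limit. Compound 2 therefore has no numerical position in the series, which stands at the limit of > 100000 nM in this assay, at which 3 of the 3 values shown sit.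

The next compound is compound 4 (`O=C(NCc1ccc(NC(=O)c2cc(Br)ccc2N2CCCC2)cc1)OCc1cccnc1`), and the change from compound 2 is bromo in place of methoxy on an aromatic carbon. Within the data shown here, the one measured step that bears on this kind of swap is a step that the two limits leave unreadable from compound 1 to compound 3, methyl in place of fluoro on an aromatic carbon, so it supplies no size to carry over. Among the measured compounds shown here, no measured step covers bromo or methoxy directly.

For the measured compounds named here, compound 2 offers only its limit of > 100000 nM as a starting point, so no step of readable size is expected in this assay, and no direction can be assigned. The likeliest report for compound 4 is expected to be another limit. The expected step is a step that the limit leaves unreadable from compound 2 to compound 4. For compound 4 the estimate is 120000 nM, with an expected range from 50000 nM to 300000 nM.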

Compound 4, half-maximal inhibitory concentration: > 100000 nM
Compound 4: only a limit was reported; the forecaster's own chance of this, stated with the estimate: 85%; the middle value does not contradict the limit.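

In this assay compound 4 gives > 100000 nM, a limit of the assay and not a number. Compound 2 also stands at a limit, so no step can be read between compound 2 and compound 4. The compounds shown leave open whether any change on the shared core moves this read-out, because all of them sit at one limit: the limit of > 100000 nM in this assay, at which 4 of the 4 values shown sit.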